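The source may report more compounds than this note shows. Statements on the series, on what has been measured and on what is new or still open speak of the compounds shown alone.

Measured compounds:
Compound 1 `COc1ccc(/C=C/C[C@@H]2C[C@@H]([C@@H](O)c3ccc(OC)c(OC)c3)CO[C@H]2c2ccccc2)cc1OC` gives 16100 nM in a functional assay on HeLa cells (Homo sapiens) for cytotoxicity, read by WST assay, with a stated time of 48 h; on this read-out higher numbers stand for weaker inhibition and lower numbers for stronger inhibition.
Compound 2 `COc1cccc(/C=C/C[C@H]2C[C@@H]([C@@H](O)c3ccccc3)CO[C@@H]2c2ccccc2)c1` gives 10900 nM in this assay.

Within the data shown here, these are the only two measured compounds, and both were examined in this assay, which reads the half-maximal inhibitory concentration for cytotoxicity on HeLa cells. Compound 1 and compound 2 sit within the usual scatter of each other, so the data so far give no ordering of the two; compound 1 simply stands beside compound 2 on the numbers shown. Among the measured compounds shown here, no pair of measured compounds differs in a single place, so no measured step is available to lean on.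

Compound 3 `COc1cccc([C@@H]2OC[C@H]([C@@H](O)c3ccc(OC)c(OC)c3)C[C@H]2C/C=C/c2ccc(OC)c(OC)c2)c1` is the unmeasured compound. It differs from compound 1 by methoxy in place of hydrogen on an aromatic carbon. For the measured compounds named here, nothing among the measured compounds isolates this change, and compound 2, which carries a 3-methoxyphenyl on its core, also differs from compound 1 elsewhere. The expectation for this assay is therefore a step no larger than the scatter, with no preferred direction.

Compound 3 is expected to give about 14000 nM, within a range of 6000 nM to 35000 nM, which corresponds to an expected step of a 1.2-fold lower number from compound 1 to compound 3 (0.06 log units; within the scatter).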

Compound 3, half-maximal inhibitory concentration: 30100 nM
For compound 3 the middle estimate is 2.2-fold (0.33 log units) below the measured one, and the stated range covers the measured number.
By their numbers in this assay, from the lowest: compounds 2, 1 and 3 (each within the scatter of the next, the first and the last beyond it).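

Among these compounds, compound 1 and compound 3 form the first measured pair that differs in one place, so this change can now be read directly. In this assay, methoxy in place of hydrogen on an aromatic carbon, meta to a large group, which turns phenyl into 3-methoxyphenyl, gives a 1.9-fold higher number from compound 1 to compound 3 (0.27 log units; within the scatter) and so shows no separation between the two compounds at this position, although it rests on this single pair. No measurement is available that could account for the size of this step.

The compounds shown leave open whether any other group at this place, such as a hydroxyl, an amine, a carboxylic acid or a longer chain such as butoxy, would give a step beyond the scatter in this assay. They also leave open whether methoxy on another carbon of this ring, or the same change made on a different background from that of compound 1, would give a step of similar size.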